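Phenyl in Place of Trifluoromethyl on the Benzoyl Group

A few compounds are considered here, and "the series" means these few. Any claim that something is new, unique, unknown or untested is made for them only; others in the source may bear on it.

Compound 3 `COc1cc(-c2nnc3n2NC(c2ccco2)C(C(=O)c2ccc(C(F)(F)F)cc2)S3)cc(OC)c1OC` carries a 4-(trifluoromethyl)phenyl on its carbonyl carbon. In a functional assay on A549 cells (Homo sapiens) for cytotoxicity, read by MTT assay, with a stated time of 48 h (a lower number here means a stronger inhibitor, a higher number a weaker inhibitor), compound 3 gives 37200 nM, the lowest of the three numbers measured: compound 1 `COc1cc(-c2nnc3n2NC(c2ccco2)C(C(=O)c2ccccc2C)S3)cc(OC)c1OC` gives 80000 nM and compound 2 `COc1cc(-c2nnc3n2NC(c2ccco2)C(C(=O)c2ccc(O)cc2)S3)cc(OC)c1OC` gives 93400 nM. The steps at this position are a 2.2-fold lower number from compound 1 to compound 3 (0.33 log units; beyond the scatter) and a 2.5-fold lower number from compound 2 to compound 3 (0.40 log units; beyond the scatter), both modest, while a 1.2-fold higher number from compound 1 to compound 2 (0.07 log units; within the scatter). Compound 4 `COc1cc(-c2nnc3n2NC(c2ccco2)C(C(=O)c2ccc(-c4ccccc4)cc2)S3)cc(OC)c1OC` differs from compound 3 by phenyl in place of trifluoromethyl on an aromatic carbon; read one bond further out, 4-(trifluoromethyl)phenyl becomes 4-phenylphenyl. Among the compounds with values here, no measured pair shows this change, so only the two modest steps at the same place bear on it, and the expected step is a 1.2-fold lower number from compound 3 to compound 4 (0.07 log units; within the scatter), hardly beyond the scatter. Compound 4 is therefore estimated at 32000 nM, within a range from 11000 nM to 95000 nM.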

Compound 4, half-maximal inhibitory concentration: > 100000 nM
Compound 4: a limit, no number; the forecaster's own chance of this, stated with the estimate: 10%; middle value at least 3.1-fold (0.49 log units) away from the limit.
By their numbers in this assay, from the lowest: compound 3; then compounds 1 and 2 (each within the scatter of the next). At a limit, above all of these: compound 4.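

In this assay compound 4 gives no number, only a limit of the assay: the limit of > 100000 nM in this assay, at which 1 of the 4 values shown sits. Phenyl in place of trifluoromethyl gives an at least 2.6-fold higher number from compound 3 to compound 4 (0.42 log units; beyond the scatter), so the change costs compound 3 its lead, and this position is the first here to yield a reading beyond the measurable range. Against the other two compounds the floors are weaker, an at least 1.0-fold higher number from compound 2 to compound 4 (0.02 log units; that floor lies within the scatter) and an at least 1.2-fold higher number from compound 1 to compound 4 (0.09 log units; that floor lies within the scatter), and these steps alone settle no size of difference.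

As far as these compounds go, how far compound 4 lies past its limit stays open. So does whether an amine, a carboxylic acid or a single fluorine at this place would match compound 3.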